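A few compounds are considered here, and "the series" means these few. Any claim that something is new, unique, unknown or untested is made for them only; others in the source may bear on it.

Measured so far:
compound 1, `CCCCCCCCc1ccc(OCC(=O)Cn2nnc(-c3ccccc3Cl)n2)cc1`, 32 nM
compound 2, `CCCCCCCCc1ccc(OCC(=O)Cn2nnc(-c3ccncc3)n2)cc1`, 24 nM
compound 3, `CCCCCCCCc1ccc(OCC(=O)Cn2nnnc2-c2cccc(Cl)c2)cc1`, 360 nM

All three numbers come from an assay on microsomes from brain for inhibition of Fatty-acid amide hydrolase 1 (Rattus norvegicus), read by fluorescence and HPLC, with a stated time of 60 min; a lower number here means a stronger inhibitor, a higher number a weaker inhibitor. Compound 3 gives the highest number of the three, which makes it the weakest inhibitor in this set: compound 1 sits at an 32 nM reading, compound 2 at 24 nM, and both gaps to compound 3 lie well beyond the scatter.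

Compound 4, `CCCCCCCCc1ccc(OCC(=O)Cn2nnnc2C(=O)OCC)cc1`, differs from compound 3 in one place: ethoxycarbonyl in place of 3-chlorophenyl on an aromatic carbon. The group that leaves carries a ring; the group that enters carries none.

For the measured compounds named here, only one measured step exists, a 1.3-fold lower number from compound 1 to compound 2 (0.12 log units; within the scatter), and there the change was from one aromatic ring to another, on a compound whose shared core is attached differently from that of compound 3. It says nothing about exchanging an aromatic ring for ethoxycarbonyl. Going by the values given here, no measured pair shows that kind of exchange, so the direction in this assay is open. Because compound 3 already gives 360 nM, the starting point is the weakest one available, and the expectation is for compound 4 to stay in a similar region, with a wide range on either side. The estimated step is a 1.4-fold higher number from compound 3 to compound 4 (0.14 log units; within the scatter). The estimate for compound 4 is 500 nM, between 100 nM and 2500 nM.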

Compound 4, half-maximal inhibitory concentration: 940 nM
For compound 4 the middle estimate is 1.9-fold (0.27 log units) below the measured one, within the range that was stated.
By their numbers in this assay, from the lowest: compounds 2 and 1 (each within the scatter of the next); then compound 3; then compound 4.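

At the aromatic carbon of the five-membered aromatic ring with 4 nitrogen, between two ring nitrogen atoms, the exchange of 3-chlorophenyl for ethoxycarbonyl gives a 2.6-fold higher number from compound 3 to compound 4 (0.42 log units; beyond the scatter) in this assay; the step is modest, but it shows that the number responds to what stands at this position. For the compounds shown here, the one earlier step only swapped one aromatic ring for another on a core attached differently, whereas this change removes the ring altogether, and the ring-free group, with its double bond outside aromatic rings and its 2 hydrogen-bond acceptors, still leaves a compound that gives a measurable inhibition reading, though a weaker one than the ring-bearing compound 3. No measurement shown here bears on which of these differences accounts for the step.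

The exchange alters ring, size and hydrogen-bond acceptors all at once, so a simple methyl group, a carboxylic acid or a small amine at the same carbon would be needed to pull these apart. Going by these compounds, whether ethoxycarbonyl would move the number the same way on the core of compound 1 also stays open.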